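The source may hold more compounds than are shown below. What is called first, only, known or untested is meant among the compounds shown, and "the series" means these compounds.

In a physicochemical assay for solubility, in phosphate buffer, at pH 7.4 (a higher number here means a more soluble compound, a lower number a less soluble compound), the three measured compounds read as follows:

Compound 1 (`CC(C)n1cc(-c2ccnc3[nH]c(C4CCNCC4)cc23)ccc1=O`) 910000 nM
Compound 2 (`CC(=O)N1CCC(c2cc3c(-c4ccc(=O)n(C(C)C)c4)ccnc3[nH]2)CC1`) 27000 nM
Compound 3 (`CC(C)Cn1cc(-c2ccnc3[nH]c(C4CCN(CC(=O)N(C)C)CC4)cc23)ccc1=O`) 390000 nM

Compound 3 with 390000 nM stands second highest of the three, lower than compound 1 and higher than compound 2. Compound 4 (`CN(C)C(=O)CN1CCC(c2cc3c(-c4ccc(=O)n(C5CCOCC5)c4)ccnc3[nH]2)CC1`) differs from it by oxan-4-yl in place of isobutyl on an aromatic nitrogen. Going by the values given here, only one step that changes a single place has been measured: a 34-fold lower number from compound 1 to compound 2 (1.53 log units; beyond the scatter) is large, but it puts acetyl in place of hydrogen on an amine nitrogen in a ring and leaves the aromatic nitrogen untouched. Among the compounds with values here, it therefore gives no size for this change, and no measured step does. In this assay no step beyond the scatter is expected, in either direction. The expected step is a 1.0-fold higher number from compound 3 to compound 4 (0.01 log units; within the scatter) and it remains an estimate. Compound 4 is estimated at 400000 nM with an expected range of 150000 nM to 900000 nM for its solubility.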

Compound 4, solubility: 840000 nM
Compound 4: middle estimate off by 2.1-fold (0.32 log units), on the low side; the range from low to high includes it.
By their numbers in this assay, from the lowest: compound 2; then compound 3; then compounds 4 and 1 (each within the scatter of the next).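

In this assay, the group on the aromatic nitrogen now has a measured step of its own: oxan-4-yl in place of isobutyl gives a 2.2-fold higher number from compound 3 to compound 4 (0.33 log units; beyond the scatter), with the rest of the structure unchanged. Going by these compounds alone, the only earlier single-place step, a 34-fold lower number from compound 1 to compound 2 (1.53 log units; beyond the scatter), lay on the amine nitrogen in a ring, so this pair is the first to show that a change on the aromatic nitrogen can move the number beyond the scatter, though the step is modest. Nothing measured here accounts for the step.

As far as these compounds go, this position rests on a single pair, so it remains open whether an open chain such as 2-methoxyethyl or an amine such as piperidin-4-yl on that nitrogen would shift the number in the same direction. From the compounds shown here alone, it is also open whether the step would carry over to compounds with a free or acetylated ring amine.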